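The source may hold more compounds than are shown below. What is called first, only, known or untested is meant among the compounds shown, and "the series" means these compounds.

Compound 1 `COc1ccc(C2=NN(C3=NC(=O)/C(=C4\C(=O)Nc5ccccc54)S3)C(c3ccc(OC)cc3)C2)cc1` and compound 2 `COc1ccc(C2=NN(C3=NC(=O)/C(=C4\C(=O)Nc5ccc(Br)cc54)S3)C(c3ccc(OC)cc3)C2)cc1` share one core and differ by a single substituent on the fused ring. In a functional assay on cells (Cancer cell lines, Homo sapiens) for cytotoxicity, read by sulforhodamine B assay, with a stated time of 48 h (a lower number here means a stronger inhibitor of growth, a higher number a weaker inhibitor of growth), compound 1 gives 92200 nM, while compound 2 gives 240 nM; the step of a 380-fold lower number from compound 1 to compound 2 (2.58 log units; beyond the scatter) makes compound 2 the lower of the two numbers. For the measured compounds named here, compound 3 `COc1ccc(C2=NN(C3=NC(=O)/C(=C4\C(=O)Nc5ccc(Cl)cc54)S3)C(c3ccc(OC)cc3)C2)cc1` keeps this arrangement, the only change being (chloro in place of bromo on an aromatic carbon). Going by the values given here, the one measured step, the large drop from compound 1 to compound 2, bears on the halogen rather than on which halogen, so a modest step is expected in this assay, estimated as a 1.7-fold higher number from compound 2 to compound 3 (0.22 log units; within the scatter). Compound 3 is therefore expected to give about 400 nM, between 120 nM and 1500 nM.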

Compound 3, concentration for 50% growth inhibition: 230 nM
Beside the measured number, compound 3's estimate is 1.7-fold (0.24 log units) above it; low and high end bracket the measured number.
By their numbers in this assay, from the lowest: compounds 3 and 2 (each within the scatter of the next); then compound 1.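

In this assay, chloro in place of bromo on this aromatic carbon leaves the number unchanged within the scatter, a 1.0-fold lower number from compound 2 to compound 3 (0.02 log units; within the scatter), so the two halogens cannot be told apart here. Chloro in place of hydrogen also gives a large step, a 400-fold lower number from compound 1 to compound 3 (2.60 log units; beyond the scatter), which shows that the large drop at this position is not confined to bromo. Nothing measured here accounts for the effect of either halogen. The compounds shown leave open whether fluoro would behave like these two halogens. They also leave open whether a non-halogen group at this position, such as methoxy, an amine or a nitrile, would give a similar number.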